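Benzyl to Ethyl on the Amine: Two Settings

A few compounds are considered here, and "the series" means these few. Any claim that something is new, unique, unknown or untested is made for them only; others in the source may bear on it.

Measured compounds:
compound 1 `CCN(CCNC(=O)c1cc(Cl)c(N)cc1OC)Cc1ccccc1`: 0.31 mg/kg
compound 2 `COc1cc(N)c(Cl)cc1C(=O)NCCN(Cc1ccccc1)Cc1ccccc1`: > 30 mg/kg
compound 3 `CNc1cc(OC)c(C(=O)NC2CCN(Cc3ccccc3)C2)cc1Cl`: 0.016 mg/kg

All three compounds share an aromatic amide core and were tested in a functional assay on the whole organism with Rattus norvegicus as the target; a higher number here means that more compound is needed for the effect, a lower number that less compound is needed. Compound 2 gives only a limit, > 30 mg/kg, so no number is known for it (the limit of > 30 mg/kg in this assay, at which 1 of the 3 values shown sits). Compound 1 is measured at 0.31 mg/kg. The change from compound 2 to compound 1 is methyl in place of phenyl on a saturated chain carbon bound to an amine nitrogen, and it brought an at least 96-fold lower number from compound 2 to compound 1 (1.98 log units; beyond the scatter). Compound 3 stands at 0.016 mg/kg, the lowest number among the measured compounds; how its core differs from that of compound 2 is not broken down here.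

Compound 4 `CCN1CCC(NC(=O)c2cc(Cl)c(NC)cc2OC)C1` has not yet been measured. It arises from compound 3 by methyl in place of phenyl on a saturated chain carbon bound to an amine nitrogen in a ring, the same kind of change as from compound 2 to compound 1, but the place is not identical: here the amine nitrogen sits in a ring. The measured step removes one phenyl where two stood, and compound 1 keeps a benzyl, whereas compound 4 keeps none. For that reason the large improvement is not expected to repeat; a step in the other direction, of moderate size, is expected, a 13-fold higher number from compound 3 to compound 4 (1.10 log units; beyond the scatter). Compound 4 is therefore estimated at 0.2 mg/kg, with a plausible range from 0.03 mg/kg to 1.5 mg/kg.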

Compound 4, dose for half-maximal effect: 10 mg/kg
Compound 4: the middle estimate sits 50-fold (1.70 log units) below what was measured; the measured number lies above the stated range.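

In this assay, the change from benzyl to ethyl on the amine brings a 630-fold higher number from compound 3 to compound 4 (2.80 log units; beyond the scatter), so a swap that lowers the number on one core raises it on the other, and the effect does not carry over between these two cores, not even in direction: the same change on two cores in this assay, an at least 96-fold lower number (1.98 log units; beyond the scatter) from compound 2 to compound 1 and a 630-fold higher number (2.80 log units; beyond the scatter) from compound 3 to compound 4, at least 60000-fold (4.78 log units) apart, beyond the scatter of two such steps. Two pairs alone do not show what reverses the step: in compound 4 the amine nitrogen sits in a ring and no benzyl remains, while in compound 1 the nitrogen sits in an open chain and one benzyl remains, and these differences cannot be separated here. Compound 2 has only a limit, > 30 mg/kg and not a number, so the step from it has a clear direction but no exact size.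

The compounds shown leave open whether any other group on the ring nitrogen of the core of compound 3, such as a propyl chain or a fluorobenzyl group, would hold the low number that benzyl gives there. They also leave open how the open-chain core would read with two ethyl groups on its amine, which would show whether one benzyl is needed on that core at all.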